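From a Hydroxypropyl Chain to a Dimethoxyphenyl Ring

The compounds below may be only part of what the source reports. "The series", "measured", "known", "first", "only" and "open" are said of these compounds alone.

Measured so far:
Compound 1 `C=CCC(c1ccc(O)c(C(C)C)c1)c1c(C)cc(OCC(=O)O)cc1C`: 90 nM
Compound 2 `Cc1cc(OCC(=O)O)cc(C)c1C(CCCO)c1ccc(O)c(C(C)C)c1`: 3600 nM

Both compounds were tested in an assay on isolated protein for binding affinity to thyroid hormone receptor beta (Homo sapiens); on this read-out lower numbers stand for tighter binding and higher numbers for weaker binding. Compound 2 stands at the highest of the two numbers; its nearest neighbour is compound 1, separated by the step of a 40-fold higher number from compound 1 to compound 2 (1.60 log units; beyond the scatter).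

Compound 3 `COc1ccc(C(c2ccc(O)c(C(C)C)c2)c2c(C)cc(OCC(=O)O)cc2C)c(OC)c1` is not yet measured. It differs from compound 2 in one place: 2,4-dimethoxyphenyl in place of 3-hydroxypropyl on a saturated chain carbon bound to two aromatic carbons. Within the data shown here, only one measured step bears on this change, namely a 40-fold higher number from compound 1 to compound 2 (1.60 log units; beyond the scatter), where the hydroxy-bearing chain entered and the number rose sharply. Compound 3 removes that chain again, but in its place puts a ring rather than the vinyl of compound 1, so the earlier step can guide only the direction, not the size. A fall in this assay is therefore expected for compound 3, smaller than the earlier rise. The expected step is a 9.0-fold lower number from compound 2 to compound 3 (0.95 log units; beyond the scatter). Compound 3 is estimated at 400 nM, within 60 nM to 3000 nM.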

Compound 3, dissociation constant: 4200 nM
For compound 3 the middle estimate is 11-fold (1.02 log units) below the measured one; measured number above the stated range.
By their numbers in this assay, from the lowest: compound 1; then compounds 2 and 3 (each within the scatter of the next).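

In this assay, putting 2,4-dimethoxyphenyl in place of 3-hydroxypropyl on a saturated chain carbon bound to two aromatic carbons gives a 1.2-fold higher number from compound 2 to compound 3 (0.07 log units; within the scatter), so this read-out does not separate a chain carrying a hydrogen-bond donor from an aromatic ring carrying none. Set against allyl, the same ring gives a 47-fold higher number from compound 1 to compound 3 (1.67 log units; beyond the scatter), which shows that removing the 3-hydroxypropyl chain does not by itself restore the low number, and allyl remains the only group here that gives it. Nothing in the data shown explains this result.

Still open, on these data alone, is whether a plain phenyl ring, without the two methoxy groups, would stand closer to allyl or to the other two groups. The same question holds for a propyl chain without its hydroxyl.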